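A few compounds are considered here, and "the series" means these few. Any claim that something is new, unique, unknown or untested is made for them only; others in the source may bear on it.

Measured so far in an ADME assay on Vero cells (Chlorocebus sabaeus) for cytotoxicity, read by XTT assay, with a stated time of 72 h; a higher number here means that more compound is tolerated, a lower number that less compound is tolerated:
- compound 1, `COc1cccc(C2NC(=O)NC(C)=C2C(=O)Nc2ccccc2Cl)c1`, gives > 100000 nM, which is a limit of the assay.
- compound 2, `CC1=C(C(=O)Oc2ccccc2)C(c2ccccc2)NC(=S)N1`, gives "non-toxic" (no number reported).
- compound 3, `CCOC(=O)C1=C(C)N(C)C(=O)NC1c1ccc(F)cc1`, gives "non-toxic" (no number reported).

Compound 3 thus stands without a single number in this assay. Of the other two entries, one is a further report without a number, and one is a limit rather than a number: the limit of > 100000 nM in this assay, at which 1 of the 3 values shown sits. Within the data shown here, nothing among the three measured compounds places compound 3 higher or lower than the others; all three were simply tolerated up to the concentrations tested, and no measured step between compounds that differ in one place is available.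

Compound 4, `COC(=O)C1=C(C)N(C)C(=O)NC1c1ccc(F)cc1`, is the next compound to be tested in this assay. It differs from compound 3 by hydrogen in place of methyl on a saturated chain carbon bound to an oxygen next to a carbonyl group, that is, the ethoxycarbonyl group of compound 3 becomes a methoxycarbonyl group in compound 4. Among the measured compounds shown here, for a change of this size, with no measured step to lean on, no step beyond the usual scatter is expected in this assay, in either direction.

Compound 4 is therefore expected to remain tolerated, with an estimated value of 100000 nM, likely between 30000 nM and 300000 nM, and most probably reported again only as a limit.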

Compound 4, half-maximal cytotoxic concentration: "non-toxic" (no number reported)
Nothing numeric was reported for compound 4; there is nothing to compare the estimate with.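

Among these compounds, compound 3 and compound 4 are both reported only as "non-toxic", with no number, so no step between them can be read in this assay. The compounds shown leave open at what concentration any of them would become toxic, and compound 1 gives only a limit: the limit of > 100000 nM in this assay, at which 1 of the 4 values shown sits.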